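Notes on the 3-nitrophenyl exchange from compound 3

The compounds below may be only part of what the source reports. "The series", "measured", "known", "first", "only" and "open" are said of these compounds alone.

- compound 1 `O=C1/C(=C/c2cccc([N+](=O)[O-])c2)CN(S(=O)(=O)c2ccc(F)cc2)C/C1=C\c1cccc([N+](=O)[O-])c1`: 3980 nM
- compound 2 `O=C1/C(=C/c2cccc([N+](=O)[O-])c2)CN(S(=O)(=O)c2ccc(F)cc2)C/C1=C\c1ccccc1F`: 7820 nM
- compound 3 `COc1cc(/C=C2\CN(S(=O)(=O)c3ccc(F)cc3)C/C(=C\c3ccccc3F)C2=O)cc(OC)c1OC`: 6340 nM

In a functional assay on SMMC-7721 cells (Homo sapiens) for cytotoxicity, read by MTT assay, with a stated time of 24 h (on this read-out lower numbers stand for stronger inhibition and higher numbers for weaker inhibition), compound 3, at 6340 nM, lies within the scatter of both other compounds. The next structure is compound 4 `COc1cc(/C=C2\CN(S(=O)(=O)c3ccc(F)cc3)C/C(=C\c3cccc([N+](=O)[O-])c3)C2=O)cc(OC)c1OC`: 3-nitrophenyl in place of 2-fluorophenyl on a double-bonded chain carbon bound to a double-bonded ring carbon, with 3-nitrophenyl in place of 2-fluorophenyl on a double-bonded chain carbon bound to a double-bonded ring carbon. The opposite exchange was measured as a 2.0-fold higher number from compound 1 to compound 2 (0.29 log units; within the scatter). The exchange of the other group gave a 1.2-fold lower number from compound 2 to compound 3 (0.09 log units; within the scatter). Both steps are small, so in this assay only a slight lowering is expected, with no step beyond the scatter. The expected step is a 1.7-fold lower number from compound 3 to compound 4 (0.22 log units; within the scatter). Compound 4 is estimated at 3800 nM, with a range from 1800 nM to 8000 nM.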

Compound 4, half-maximal inhibitory concentration: 4900 nM
Compound 4: middle estimate off by 1.3-fold (0.11 log units), on the low side, within the range that was stated.
By their numbers in this assay, from the lowest: compounds 1, 4, 3 and 2 (each within the scatter of the next).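

In this assay, the exchange of 2-fluorophenyl for 3-nitrophenyl gives a 1.3-fold lower number from compound 3 to compound 4 (0.11 log units; within the scatter), while the other two steps to compound 4 are a 1.6-fold lower number from compound 2 to compound 4 (0.20 log units; within the scatter) and a 1.2-fold higher number from compound 1 to compound 4 (0.09 log units; within the scatter). The exchange between 3-nitrophenyl and 2-fluorophenyl now reads alike on two cores: the same change on two cores in this assay, a 2.0-fold higher number (0.29 log units; within the scatter) from compound 1 to compound 2 and a 1.3-fold higher number (0.11 log units; within the scatter) from compound 4 to compound 3, 1.5-fold (0.18 log units) apart, within the scatter of two such steps. The exchange involving 3,4,5-trimethoxyphenyl also reads alike on two cores: the same change on two cores in this assay, a 1.2-fold lower number (0.09 log units; within the scatter) from compound 2 to compound 3 and a 1.2-fold higher number (0.09 log units; within the scatter) from compound 1 to compound 4, 1.5-fold (0.18 log units) apart, within the scatter of two such steps.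

The three aryl groups shown are not separated at this place, as every step stays within the scatter. Still open, going by these compounds, is whether a phenyl carrying an amine or a carboxylic acid would give a step beyond the scatter.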